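Methyl to Hydrogen on an Aromatic Carbon: Compound 3 to 4

The source may report more compounds than this note shows. Statements on the series, on what has been measured and on what is new or still open speak of the compounds shown alone.

Compound 1 `c1ccc2[nH]c(-n3cccn3)cc2c1`: in a functional assay on PC-3 cells (Homo sapiens) for cytotoxicity, read by MTT assay, with a stated time of 72 h (a lower number here means a stronger inhibitor, a higher number a weaker inhibitor), compound 1 reaches only the limit > 100000 nM.
Compound 2 `O=C1NC(=O)c2c1c1c3cc(O)ccc3[nH]c1c1cccn21`: in this assay compound 2 likewise gives only the limit > 100000 nM.
Compound 3 `Cc1ccc2[nH]c(-n3cccn3)c(C3=C(Br)C(=O)NC3=O)c2c1`: in this assay compound 3 gives 26000 nM.

Among the measured compounds shown here, of the three measured compounds, compound 3 is the only one with a number; compounds 1 and 2 sit at the limit of > 100000 nM in this assay, at which 2 of the 3 values shown sit. Compound 3 therefore stands alone as a weak but measurable inhibitor, and nothing in the measured set allows a direct comparison of one change in one place.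

Compound 4 `O=C1NC(=O)C(c2c(-n3cccn3)[nH]c3ccccc23)=C1Br` is the next compound, differing from compound 3 in a single respect: hydrogen in place of methyl on an aromatic carbon. For the measured compounds named here, the loss of a single carbon at this place is a small change, and no measured pair shows what such a change does here. The expectation is a step no larger than the usual scatter, if anything toward a weaker inhibitor. Compound 4 is thus estimated at 35000 nM, between 12000 nM and 100000 nM, which means an expected step of a 1.3-fold higher number from compound 3 to compound 4 (0.13 log units; within the scatter).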

Compound 4, half-maximal inhibitory concentration: 27000 nM
For compound 4 the middle estimate is 1.3-fold (0.11 log units) above the measured one, within the range that was stated.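

In this assay, among the compounds shown here, the exchange of methyl for hydrogen on the aromatic carbon gives a 1.0-fold higher number from compound 3 to compound 4 (0.02 log units; within the scatter) and so provides the first comparison in this set between compounds that differ in one place. Compound 3 and compound 4 cannot be told apart in this assay, which shows that the methyl at this position can be lost without any difference beyond the scatter. Nothing measured here offers a reason for this result.

At this carbon, only methyl and hydrogen are shown, and neither of them tests what a larger or differently built group would do. From the compounds shown here alone, whether a methoxy group, an amine, a carboxylic acid or a longer alkyl chain at this place would also leave the reading unmoved, or would shift it in either direction, remains open.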